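Series notes: carboxy-to-hydroxy-thiane dioxide swap on the amide

A few compounds are considered here, and "the series" means these few. Any claim that something is new, unique, unknown or untested is made for them only; others in the source may bear on it.

Compound 2 `C[C@]1(C(=O)N2CC[C@](c3ccc(C(F)(C(F)(F)F)C(F)(F)F)cc3)(S(=O)(=O)c3ccc(F)cc3)C2)CC[C@@H](C(=O)O)CC1` gives 100% in an ADME assay on microsomes from liver (Mus musculus) for metabolic stability, with a stated time of 10 min (a higher number here means that more of the compound is left, a lower number that less of the compound is left), the highest of the three numbers in hand. Compound 1 `C[C@]1(C(=O)O)CC[C@H](C(=O)N2CC[C@](c3ccc(C(F)(C(F)(F)F)C(F)(F)F)cc3)(S(=O)(=O)c3ccc(F)cc3)C2)CC1` stands nearest with 93%; the step of a number 7 percentage points higher from compound 1 to compound 2 (within the scatter) is within the scatter, so the two are not separable. Compound 3 `O=C([C@H]1CC[C@H](CO)CC1)N1CC[C@](c2ccc(C(F)(C(F)(F)F)C(F)(F)F)cc2)(S(=O)(=O)c2ccc(F)cc2)C1` stands furthest with 63%, and the step of a number 37 percentage points lower from compound 2 to compound 3 (beyond the scatter) is the one clear move in the set; a number 30 percentage points lower from compound 1 to compound 3 (beyond the scatter) points the same way.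

Compound 4 `O=C(N1CC[C@](c2ccc(C(F)(C(F)(F)F)C(F)(F)F)cc2)(S(=O)(=O)c2ccc(F)cc2)C1)C1(O)CCS(=O)(=O)CC1` has not been measured. Its change from compound 2 is 4-hydroxy-1,1-dioxothian-4-yl in place of 4-carboxy-1-methylcyclohexyl on a carbonyl carbon. The step that bears on it most is a number 37 percentage points lower from compound 2 to compound 3 (beyond the scatter), where the 4-carboxy-1-methylcyclohexyl group also left the carbonyl carbon and a group bearing a hydroxyl entered; a number 30 percentage points lower from compound 1 to compound 3 (beyond the scatter) is the same kind of move from the other acid. Compound 4 likewise carries a hydroxyl in place of the carboxy group, though with a ring of a different kind. On that basis a downward step is expected for compound 4, of the order seen for compound 3, as a number 32 percentage points lower from compound 2 to compound 4 (beyond the scatter). Compound 4 is therefore estimated at 68%, with a range from 45% to 90%.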

Compound 4, percent of the compound remaining: 90%
Beside the measured number, compound 4's estimate is 22 percentage points below it; low and high end bracket the measured number.
By their numbers in this assay, from the lowest: compound 3; then compounds 4, 1 and 2 (each within the scatter of the next).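

Notes on the result: in this assay, a hydroxyl-bearing group on this carbonyl carbon does not by itself bring the fall seen with compound 3, since the 4-hydroxy-1,1-dioxothian-4-yl group gives a number 27 percentage points higher from compound 3 to compound 4 (beyond the scatter). Among these compounds, the comparisons with the two acids, a number 10 percentage points lower from compound 2 to compound 4 (within the scatter) and a number 3 percentage points lower from compound 1 to compound 4 (within the scatter), do not separate compound 4 from either, so a carboxy group is not required at this position for a number in that range, and compound 3 remains the only compound here that stands apart from the others. No measurement at hand accounts for the gap between the two hydroxyl-bearing groups.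

From the compounds shown here alone, the step from compound 3 to compound 4 changes the ring and the form of the hydroxyl-bearing substituent together, so the part played by each stays open; 4-hydroxycyclohexyl, with the hydroxyl on a ring of carbon only, would separate the two. Going by these compounds, whether the high numbers extend beyond carboxy and hydroxyl groups also stays open, for example to an amine or a primary carboxamide on the same ring.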